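Replacing amino with 2-methylphenyl on the ring nitrogen

The source may hold more compounds than are shown below. What is called first, only, known or untested is meant among the compounds shown, and "the series" means these compounds.

Compound 2, `NN1C(=O)C(c2ccccc2)CC(c2ccccc2)C1=O`, gives 10 mg/kg in a functional assay on the whole organism (strain Swiss albino) with Mus musculus as the target, in the maximal electroshock model, with a stated time of 2 h; a higher number here means that more compound is needed for the effect, a lower number that less compound is needed. Compound 1, `O=C1NC(=O)C(c2ccccc2)CC1c1ccccc1`, gives 11 mg/kg in this assay, and the step of a 1.1-fold lower number from compound 1 to compound 2 (0.04 log units; within the scatter) shows that the two numbers lie within the scatter of each other. Compound 3, `Cc1ccccc1N1C(=O)C(c2ccccc2)CC(c2ccccc2)C1=O`, differs from compound 2 by 2-methylphenyl in place of amino on an amide-type nitrogen in a ring. Among the measured compounds shown here, the only measured step at this nitrogen is the small 1.1-fold lower number from compound 1 to compound 2 (0.04 log units; within the scatter), and no measured pair shows an aromatic ring there, so a change beyond the scatter is not expected, though the gap in the data leaves room for one. For compound 3 the estimated value is 15 mg/kg, within 6 mg/kg to 40 mg/kg, an expected step of a 1.5-fold higher number from compound 2 to compound 3 (0.18 log units; within the scatter).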

Compound 3, dose for half-maximal effect: 21.5 mg/kg
Compound 3: middle estimate off by 1.4-fold (0.16 log units), on the low side, within the range that was stated.
By their numbers in this assay, from the lowest: compounds 2, 1 and 3 (each within the scatter of the next, the first and the last beyond it).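

Against hydrogen on this nitrogen, 2-methylphenyl gives a 2.0-fold higher number from compound 1 to compound 3 (0.29 log units; within the scatter) and so stays close, while against amino it gives a 2.2-fold higher number from compound 2 to compound 3 (0.33 log units; beyond the scatter) and so makes the first step at this position to pass the scatter, though only modestly. A group with far more heavy atoms than amino or hydrogen is therefore carried here at a small cost in dose. Nothing available explains this rise.

On these data alone, whether plain phenyl or a short chain such as ethyl on this nitrogen would sit closer to compound 2 or to compound 3 stays open.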